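The compounds below may be only part of what the source reports. "The series", "measured", "known", "first", "only" and "open" are said of these compounds alone.

In a functional assay on HT-29 cells (Homo sapiens) for cytotoxicity, read by MTT assay, with a stated time of 72 h (on this read-out lower numbers stand for stronger inhibition and higher numbers for weaker inhibition), three compounds have been measured so far. Compound 1 `COC(=O)c1sc2cc(OC)ccc2c1Nc1cc(OC)c(OC)c(OC)c1` gives 0.9 nM, compound 3 `CCOC(=O)c1sc2cc(C)ccc2c1Nc1cc(OC)c(OC)c(OC)c1` gives 6 nM, and compound 2 `CCOC(=O)c1sc2ccccc2c1Nc1cc(OC)c(OC)c(OC)c1` gives 1610 nM. Compound 3 thus holds the second highest of the three numbers, beyond the scatter from both of the others.

Compound 4 `CCOC(=O)c1sc2cc(OC)ccc2c1Nc1cc(OC)c(OC)c(OC)c1` keeps all of compound 3 except one group: methoxy in place of methyl on an aromatic carbon. Among the compounds with values here, only one measured step involves this place, a 270-fold lower number from compound 2 to compound 3 (2.43 log units; beyond the scatter), where methyl took the place of hydrogen. That step was large, but it does not compare methoxy with methyl directly. Compound 1 carries methoxy at the same place on a different ester and reaches 0.9 nM, which suggests that the number may fall further. A modest step toward a lower number is therefore expected, and it may not clear the scatter: a 2.4-fold lower number from compound 3 to compound 4 (0.38 log units; beyond the scatter). For compound 4 the estimated value is 2.5 nM, with an expected range of 0.6 nM to 10 nM.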

Compound 4, half-maximal inhibitory concentration: 10.2 nM
Compound 4: middle estimate off by 4.1-fold (0.61 log units), on the low side; measured number outside the range, above it.
By their numbers in this assay, from the lowest: compound 1; then compounds 3 and 4 (each within the scatter of the next); then compound 2.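

In this assay the swap of methyl for methoxy at this place gives a 1.7-fold higher number from compound 3 to compound 4 (0.23 log units; within the scatter) and so the two groups cannot be told apart here. Either group does far more than hydrogen: methoxy in place of hydrogen gives a 160-fold lower number from compound 2 to compound 4 (2.20 log units; beyond the scatter) and this large step stands alongside a 270-fold lower number from compound 2 to compound 3 (2.43 log units; beyond the scatter) for methyl, so among these compounds, filling this place counts for more than the choice between the two groups. With methoxy kept, the ester matters as well: methyl in place of hydrogen on the saturated chain carbon bound to an oxygen next to the carbonyl group gives an 11-fold higher number from compound 1 to compound 4 (1.05 log units; beyond the scatter) as a large step of its own.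

Nothing given here explains any of these steps. Going by these compounds, whether chlorine or an amine at this place would hold the number as low as methyl and methoxy do remains open.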